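Compound 2 to compound 3: an aryl exchange

The compounds below may be only part of what the source reports. "The series", "measured", "known", "first", "only" and "open" are said of these compounds alone.

Compound 1 (`NC1=NC2(CCOCC2)N(OCCCOc2ccccc2)C(N)=N1`) has no result in a functional assay on MDA-MB-231 cells (Homo sapiens) for antiproliferative activity, read by MTT assay, with a stated time of 72 h; on this read-out lower numbers stand for stronger inhibition and higher numbers for weaker inhibition ("not determined" (no result reported)). Going by the values given here, compound 2 (`Cc1cc(C)cc(OCCCON2C(N)=NC(N)=NC23CCOCC3)c1`) gives the only number so far (3570 nM), so its standing cannot be ranked. Compound 3 (`NC1=NC2(CCOCC2)N(OCCCOc2ccccc2Br)C(N)=N1`) carries 2-bromophenyl in place of 3,5-dimethylphenyl on an oxygen on a saturated carbon. Among the compounds with values here, no measured step exists to guide the expectation, so no shift beyond the usual scatter is expected in this assay, and no direction is favoured. The estimated step is small (a 1.2-fold lower number from compound 2 to compound 3 (0.08 log units; within the scatter)). For compound 3 the expected value is (3000 nM), with an estimated range from (1000 nM) to (9000 nM).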

Compound 3, half-maximal inhibitory concentration: 910 nM
Compound 3: middle estimate off by 3.3-fold (0.52 log units), on the high side; the whole stated range lies above it.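

In this assay, going by these compounds alone, the aryl group on this oxygen is not interchangeable: 2-bromophenyl in place of 3,5-dimethylphenyl gives a 3.9-fold lower number from compound 2 to compound 3 (0.59 log units; beyond the scatter), the first measured step. The two groups differ in substituent identity, number and placement, so this single step cannot assign the change to any one of these. No measured evidence on the origin of the step is available. Open, as far as these compounds go, is how 2-chlorophenyl, or an aryl ring carrying an amine or a carboxylic acid, would read here, and how a longer chain on this oxygen would read.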